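This account rests on a few compounds, and the source may have more. Where it says the series, first, only, none or still open, it means among the compounds named here.

Measured compounds:
Compound 1, `Cc1c(C(=O)Nc2ccc(C(F)(F)F)cc2)cnn1Cc1ccc(F)cc1`, in a functional assay with Homo sapiens as the target (a higher number here means a weaker inhibitor, a lower number a stronger inhibitor), compound 1 gives 3600 nM.
Compound 2, `Cc1c(C(=O)Nc2cccc(F)c2)cnn1-c1ccc(F)cc1`, in this assay compound 2 gives 3000 nM.

Compound 2 sits alongside compound 1 on these two numbers; the gap between them lies within the usual scatter of such measurements, so the two cannot be told apart. Both compounds share the same core and the same amide linkage.

Compound 3, `Cc1ccccc1NC(=O)c1cnn(-c2ccc(F)cc2)c1C`, has not yet been measured in this assay. It differs from compound 2 in one place: 2-methylphenyl in place of 3-fluorophenyl on an amide-type nitrogen.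

Among the measured compounds shown here, no pair of measured compounds differs by just such a change, so nothing here shows how this assay responds to it. The expectation is therefore a step of a 1.2-fold higher number from compound 2 to compound 3 (0.07 log units; within the scatter) of no clear direction, not beyond the scatter. Compound 3 is estimated at 3500 nM, with a range from 1200 nM to 10000 nM.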

Compound 3, half-maximal inhibitory concentration: 1100 nM
Compound 3: middle estimate off by 3.2-fold (0.50 log units), on the high side; the whole stated range lies above it.
By their numbers in this assay, from the lowest: compound 3; then compounds 2 and 1 (each within the scatter of the next).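

On an amide-type nitrogen, 2-methylphenyl in place of 3-fluorophenyl gives a 2.7-fold lower number from compound 2 to compound 3 (0.44 log units; beyond the scatter) in this assay and so makes compound 3 the stronger inhibitor of the pair. Among the compounds shown here, this is the first single-place change, and it shows that the group on this nitrogen can shift the result beyond the scatter. The two groups match in heavy-atom count, in their six-membered aromatic ring and in having no hydrogen-bond donors or acceptors, and nothing measured here explains the difference between them.

This one step changes both the kind of substituent and its numbered place on the ring, so it cannot show which of the two matters. On these data alone, how the assay would respond to an amine, a carboxylic acid or a longer chain on that ring remains open.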